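A few compounds are considered here, and "the series" means these few. Any claim that something is new, unique, unknown or untested is made for them only; others in the source may bear on it.

Compound 1 `N#CC1=C(/N=C/Nc2ccc([N+](=O)[O-])cc2)N(c2ccccc2)C(=O)N2CCCCC(N3CCCC3)C12` is the reference point of this account. In a functional assay on the whole organism (strain albino) for inhibition, with Rattus norvegicus as the target, read by paw edema, with a stated time of 1 h, at a dose of 20 mmol/kg by the intraperitoneal route (a higher number here means more inhibition at the dose given (going by the name of the read-out), a lower number less inhibition), compound 1 gives 32.1%, which places it second highest of the three compounds measured. Its nearest neighbour is compound 2 `COc1ccc(N/C=N/C2=C(C#N)C3C(N4CCCC4)CCCCN3C(=O)N2c2ccccc2)cc1`, which in this assay gives 20.6%; the step of a number 11.5 percentage points lower from compound 1 to compound 2 (beyond the scatter) comes with a methoxy in place of the nitro on an aromatic carbon. For the measured compounds named here, the furthest is compound 3 `N#Cc1c2n(c(=O)n(-c3ccccc3)c1=N)CCCCC2N1CCCC1`, which in this assay gives 84.6%, a considerably higher number, though no single-change step links it to compound 1.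

Compound 4 `CCOC(=O)C(=O)NC1=C(C#N)C2C(N3CCCC3)CCCCN2C(=O)N1c1ccccc1` is not yet measured. It differs from compound 1 in one place: a group of 8 heavy atoms (4 carbon, 1 nitrogen, 3 oxygen; no ring) in place of a group of 12 heavy atoms (7 carbon, 3 nitrogen, 2 oxygen; one six-membered aromatic ring of carbon only), on a double-bonded ring carbon. Going by the values given here, of the measured steps, only the one from compound 1 to compound 2 bears on this position at all, and it altered a substituent on the departing aromatic ring rather than removing that ring, so it is only indirect guidance. The values of compound 3 show that a smaller group on the shared core can go with a much higher number. Compound 4 is therefore expected to land somewhat above compound 1, with the step of a number 9.9 percentage points higher from compound 1 to compound 4 (within the scatter) as the estimate, while a result within the scatter would not surprise. The expected value for compound 4 is 42%, with a range from 15% to 70%.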

Compound 4, a percentage reported as inhibition, in the whole organism at one dose (the size of the read-out at that dose, not a potency): 71.2%
The estimate for compound 4 lay 29.2 percentage points below the measured number; the measured number lies above the stated range.
By their numbers in this assay, from the lowest: compound 2; then compound 1; then compound 4; then compound 3.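

At the double-bonded ring carbon, the group bearing the aromatic ring can be given up altogether in this assay: with ((ethoxycarbonyl)carbonyl)amino entering, the readout shows a number 39.1 percentage points higher from compound 1 to compound 4 (beyond the scatter) and, against the methoxy-bearing group, a number 50.6 percentage points higher from compound 2 to compound 4 (beyond the scatter) in the same direction. Both steps are large, whereas the earlier change on the aromatic ring itself, a number 11.5 percentage points lower from compound 1 to compound 2 (beyond the scatter), was modest, so among these compounds replacing the whole group at this position moves the number more than changing a substituent on its ring, even though the leaving and entering groups have the same counts of hydrogen-bond donors and acceptors. Nothing measured here explains the rise.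

The compounds shown do not separate the loss of the aromatic ring from the arrival of the new group, so it stays unclear whether any small group at this position would give a similar number. Nor do they show which part of ((ethoxycarbonyl)carbonyl)amino matters, a question that a free carboxylic acid in place of the ethyl ester, a plain acetylamino group or an unsubstituted amine at the same carbon would address.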